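A few compounds are considered here, and "the series" means these few. Any claim that something is new, unique, unknown or untested is made for them only; others in the source may bear on it.

Working notes on the series. Three aryl variants on the shared core have been read in a functional assay on SGC-7901 cells (Homo sapiens) for inhibition, read by MTT assay, with a stated time of 24 h; a lower number here means a stronger inhibitor, a higher number a weaker inhibitor: compound 1 (`CC1(C)[C@H]2CC[C@]1(C)N(Cc1cn(-c3ccccc3C#N)nn1)C(=O)C2`) gives 260 nM, compound 2 (`CC1(C)[C@H]2CC[C@]1(C)N(Cc1cn(-c3cccc(C#N)c3)nn1)C(=O)C2`) gives 250 nM, and compound 3 (`CC1(C)[C@H]2CC[C@]1(C)N(Cc1cn(-c3ccccc3O)nn1)C(=O)C2`) gives 410 nM. Compound 3 stands within the scatter of both others, as shown by a 1.6-fold higher number from compound 1 to compound 3 (0.20 log units; within the scatter) and a 1.6-fold higher number from compound 2 to compound 3 (0.21 log units; within the scatter).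

The next change leads to compound 4 (`COc1ccc(-n2cc(CN3C(=O)C[C@@H]4CC[C@@]3(C)C4(C)C)nn2)cc1`): 4-methoxyphenyl in place of 2-hydroxyphenyl on an aromatic nitrogen, (4-methoxyphenyl in place of 2-hydroxyphenyl on an aromatic nitrogen). Among the compounds with values here, no measured compound carries 4-methoxyphenyl, so no measured step isolates this exact swap. The nearest evidence is the set of aryl exchanges at the same nitrogen. Exchanging 2-cyanophenyl for 3-cyanophenyl gives a 1.0-fold lower number from compound 1 to compound 2 (0.02 log units; within the scatter), and the two steps that lead to compound 3 are of similar modest size. All three lie within the scatter, so no step beyond the scatter is expected in this assay, and no direction can be assigned with confidence.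

The expected change is small: a 1.4-fold lower number from compound 3 to compound 4 (0.14 log units; within the scatter).

For compound 4 the estimated value is 300 nM, with an expected range of 130 nM to 700 nM.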

Compound 4, half-maximal inhibitory concentration: 480 nM
Compound 4: the middle estimate sits 1.6-fold (0.20 log units) below what was measured, and the stated range covers the measured number.
By their numbers in this assay, from the lowest: compounds 2, 1, 3 and 4 (each within the scatter of the next).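

With 4-methoxyphenyl on the aromatic nitrogen, this assay gives a 1.2-fold higher number from compound 3 to compound 4 (0.07 log units; within the scatter), so replacing 2-hydroxyphenyl, which has 1 hydrogen-bond donor, with a group that has 0 hydrogen-bond donors produces no step beyond the scatter. Within the data shown here, the two nitrile comparisons, a 1.9-fold higher number from compound 2 to compound 4 (0.28 log units; within the scatter) and a 1.8-fold higher number from compound 1 to compound 4 (0.27 log units; within the scatter), are the largest steps so far, yet they too stay within the scatter, and the four aryl groups now read at this position, including the first with a substituent named at the 4-position of the phenyl ring, cannot be separated by single steps. Nothing available bears on why these aryl exchanges leave the number within the scatter.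

The step from compound 3 to compound 4 changes both the substituent and its place on the phenyl ring, so 2-methoxyphenyl or 4-hydroxyphenyl would be needed to separate the two changes. Going by these compounds, it also remains open whether a group such as 4-aminophenyl, 4-carboxyphenyl or a longer alkyl chain on the same nitrogen would produce a step beyond the scatter in this assay.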